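Chloro to Fluoro, Repeated on a Second Core

A few compounds are considered here, and "the series" means these few. Any claim that something is new, unique, unknown or untested is made for them only; others in the source may bear on it.

Compound 1 `COc1ccc(Cl)c(-c2nnc3sc(-c4ccnc(Cl)c4)nn23)c1` and compound 3 `COc1ccc(Cl)c(-c2nnc3sc(-c4ccnc(F)c4)nn23)c1` share one core; compound 2 `COc1ccc(Cc2nnc3sc(-c4ccnc(Cl)c4)nn23)cc1OC` and compound 4 `COc1ccc(Cc2nnc3sc(-c4ccnc(F)c4)nn23)cc1OC` share another. The difference between the two cores is not broken down here. What joins the pairs is a single change, made once in each: fluoro in place of chloro on an aromatic carbon in the first pair and fluoro in place of chloro on an aromatic carbon in the second, both at a place described in the same words.

In a functional assay on the whole organism (strain Wistar Albino) for inhibition, with Rattus norvegicus as the target, read by paw edema, with a stated time of 3 h, at a dose of 20 mg/kg (a higher number here means more inhibition at the dose given (going by the name of the read-out), a lower number less inhibition), compound 1 gives 23.5%, and compound 3 gives 25.9%. In this assay compound 2 gives 22.5%. The measured step reads a number 2.4 percentage points higher from compound 1 to compound 3 (within the scatter), so the swap of one halogen for the other left the read-out essentially where it was.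

Compound 4 has not yet been measured in this assay. Going by the values given here, since the change is the same kind and the only measured example, a number 2.4 percentage points higher from compound 1 to compound 3 (within the scatter), stayed within the scatter, the step of a number 2.5 percentage points higher from compound 2 to compound 4 (within the scatter) is expected to be similarly small. Compound 4 is therefore estimated to give about 25%, with a likely span from 15% to 35%.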

Compound 4, a percentage reported as inhibition, in the whole organism at one dose (the size of the read-out at that dose, not a potency): 16.7%
Beside the measured number, compound 4's estimate is 8.3 percentage points above it, and the stated range covers the measured number.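

In this assay, going from 2-chloropyridin-4-yl to 2-fluoropyridin-4-yl on the second core gives a number 5.8 percentage points lower from compound 2 to compound 4 (within the scatter), so here too the swap leaves the read-out within the usual scatter. Set side by side, the results on the two cores agree: the same change on two cores in this assay, a number 2.4 percentage points higher (within the scatter) from compound 1 to compound 3 and a number 5.8 percentage points lower (within the scatter) from compound 2 to compound 4, 8.2 percentage points apart, within the scatter of two such steps. This shows that, in these two pairs, the change carries from one core to the other without a difference that can be told from scatter, and the opposite directions of the two steps cannot be read as a real difference; it does not show that the change would behave the same way on any other core, or at another dose or time.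

As far as these compounds go, whether a group other than a halogen at this place, such as an amine or a nitrile, would move the read-out beyond the scatter remains open. Also open, from the compounds shown here alone, is whether the two cores would still agree with a larger change there, such as a carboxylic acid.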